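This account rests on a few compounds, and the source may have more. Where it says the series, first, only, none or still open, it means among the compounds named here.

Measured so far:
compound 1 `Cc1ccc(C(=O)N2N=C(c3ccc(N4CCN(C)CC4)cc3)CC2c2ccc(N(C)C)cc2)cc1`: -0.4%
compound 2 `Cc1ccc(S(=O)(=O)N2N=C(c3ccc(N4CCN(C)CC4)cc3)CC2c2ccc(N(C)C)cc2)cc1`: 38.1%

In a functional assay on NCI-H1975 cells (Homo sapiens) for inhibition, read by sulforhodamine B assay, tested at 10 uM (on this read-out lower numbers stand for less inhibition and higher numbers for more inhibition at the one concentration tested (going by the name of the read-out)), compound 2 gives 38.1%, the higher of the two numbers, while compound 1 gives -0.4%. Going by the values given here, the only measured step, a number 38.5 percentage points higher from compound 1 to compound 2 (beyond the scatter), concerns the group on the amine nitrogen in a ring, not the aromatic ring that changes next. Compound 3 `CN1CCN(c2ccc(C3=NN(S(=O)(=O)c4ccc(Br)cc4)C(c4ccc(N(C)C)cc4)C3)cc2)CC1` differs from compound 2 by bromo in place of methyl on an aromatic carbon. Among the compounds with values here, no measured step bears on this change, so no shift beyond the scatter is expected. Compound 3 is therefore estimated at 38%, with a range from 18% to 58%. The expected step is a number 0.1 percentage points lower from compound 2 to compound 3 (within the scatter).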

Compound 3, a percentage reported as inhibition, at one concentration (the size of the read-out at that concentration, not a potency): 70.8%
The estimate for compound 3 lay 32.8 percentage points below the measured number; the measured number lies above the stated range.
By their numbers in this assay, from the lowest: compound 1; then compound 2; then compound 3.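

In this assay, swapping a single atom on the aromatic ring of the sulfonyl group, bromo in place of methyl, gives a number 32.7 percentage points higher from compound 2 to compound 3 (beyond the scatter). This position, para to a large group, therefore responds strongly, which the earlier pair could not show. Changing both places at once, (4-bromophenyl)sulfonyl in place of (4-methylphenyl)carbonyl gives a number 71.2 percentage points higher from compound 1 to compound 3 (beyond the scatter). Nothing available explains why bromo has this effect. On these data alone, it remains open whether chloro, methoxy or an amine at this position would behave like bromo, and whether bromo would have the same effect on the carbonyl compound.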